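A few compounds are considered here, and "the series" means these few. Any claim that something is new, unique, unknown or untested is made for them only; others in the source may bear on it.

Measured in an ADME assay on the whole organism (Rattus norvegicus) for pharmacokinetics, at a dose of 1 mg/kg by the intravenous route; on this read-out lower numbers stand for slow clearance and higher numbers for fast clearance:
- compound 1 `O=C(c1cn[nH]c1)N1CCC(C(=O)N2N=CCC2c2ccccc2)CC1`: 46 mL/min/kg
- compound 2 `Cc1nnc(N2CCC(C(=O)N3N=CC[C@H]3c3cc(F)cc(F)c3)CC2)o1`: 14 mL/min/kg
- compound 3 `O=C(c1c[nH]nn1)N1CCC(C(=O)N2N=CCC2c2ccccc2)CC1`: 37 mL/min/kg

Compound 3, at 37 mL/min/kg, sits within the usual scatter of compound 1, at 46 mL/min/kg. Together these two form the upper pair of the three numbers. Compound 2, at 14 mL/min/kg, lies lower than compound 3 by more than the scatter, but it differs from compound 3 in more than one place, so it says little about a single swap.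

The next compound to be tested is compound 4 `O=C(c1cocn1)N1CCC(C(=O)N2N=CCC2c2ccccc2)CC1`. It has 1,3-oxazol-4-yl in place of 1H-1,2,3-triazol-4-yl on a carbonyl carbon.

Among the compounds with values here, only one measured step bears on this change, as it also swaps one five-membered aromatic ring for another at the same carbonyl carbon. That step, a 1.2-fold lower number from compound 1 to compound 3 (0.09 log units; within the scatter), stayed within the scatter. Within the data shown here, no measured compound carries the 1,3-oxazol-4-yl group, so this expectation rests on a single comparison. On that basis, no step beyond the scatter is expected in this assay.

The expected change is a 1.1-fold higher number from compound 3 to compound 4 (0.03 log units; within the scatter).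

For compound 4 the estimated clearance is 40 mL/min/kg, with an expected range from 22 mL/min/kg to 70 mL/min/kg.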

Compound 4, clearance: 58 mL/min/kg
Compound 4: the middle estimate sits 1.5-fold (0.16 log units) below what was measured, within the range that was stated.
By their numbers in this assay, from the lowest: compound 2; then compounds 3, 1 and 4 (each within the scatter of the next).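

In this assay the change on this carbonyl carbon gives a 1.6-fold higher number from compound 3 to compound 4 (0.20 log units; within the scatter) and, set against the pyrazole, a 1.3-fold higher number from compound 1 to compound 4 (0.10 log units; within the scatter) for the same incoming ring. With 1,3-oxazol-4-yl added, the shared core has now been tested with three different five-membered aromatic rings at this place, and every step printed among them stays within the usual scatter of repeated measurements. This swap also takes the count of hydrogen-bond donors on the group from 1 in 1H-1,2,3-triazol-4-yl to 0 in 1,3-oxazol-4-yl, and the clearance number does not shift beyond that scatter, although no information is available to explain why these rings behave alike.

These compounds leave open whether a group of another kind on this carbonyl carbon, such as a six-membered pyridin-3-yl ring, a dimethylamino group or a longer alkyl chain, would produce a step beyond the scatter. Within the data shown here, they also leave open which of its several differences sets compound 2 apart, since no measured compound differs from it in only one place.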